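Amide aryl swap in the quinoline anilide series

The source may report more compounds than this note shows. Statements on the series, on what has been measured and on what is new or still open speak of the compounds shown alone.

Measured compounds: compound 1 `CCN1CCN(c2cc(C)c3cc(NC(=O)c4ccc(C)cc4)ccc3n2)CC1` gives 11400 nM; compound 2 `CCNc1cc(C)c2cc(NC(=O)c3ccc(Cl)c(Cl)c3)ccc2n1` gives 28200 nM; compound 3 `CCN(CC)c1cc(C)c2cc(NC(=O)c3ccc(Cl)c(Cl)c3)ccc2n1` gives 41200 nM.

In a functional assay on SK-BR-3 cells (Homo sapiens) for antiproliferative activity, read by MTT assay, with a stated time of 72 h (a lower number here means a stronger inhibitor, a higher number a weaker inhibitor), compound 1 stands lowest of the three numbers, with compound 2 the nearest and compound 3 the furthest, both beyond the scatter.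

For the measured compounds named here, the one measured step, a 1.5-fold higher number from compound 2 to compound 3 (0.16 log units; within the scatter), changes the substituent on the ring nitrogen side of the core and leaves the amide aryl group untouched, so it tells nothing about the change now in question.

Compound 4 `CCN1CCN(c2cc(C)c3cc(NC(=O)c4cc5ccccc5[nH]4)ccc3n2)CC1` differs from compound 1 as follows: 1H-indol-2-yl in place of 4-methylphenyl on a carbonyl carbon. Going by the values given here, no measured pair varies this group; compounds 2 and 3 carry a different amide aryl group but also a different ring-nitrogen substituent, so their values cannot be set against compound 1 for this change alone. The size and direction of the step in this assay are therefore unknown, and the expectation leans on compound 1 with a wide range.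

Compound 4 is estimated at 9000 nM (range 2000 nM to 40000 nM), an expected step of a 1.3-fold lower number from compound 1 to compound 4 (0.10 log units; within the scatter).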

Compound 4, half-maximal inhibitory concentration: 2550 nM
Compound 4: the middle estimate sits 3.5-fold (0.55 log units) above what was measured; the range from low to high includes it.
By their numbers in this assay, from the lowest: compound 4; then compound 1; then compounds 2 and 3 (each within the scatter of the next).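

The amide aryl group on the carbonyl carbon proves to be a position that moves the number: with the rest of the molecule unchanged, 1H-indol-2-yl in place of 4-methylphenyl gives, in this assay, a 4.5-fold lower number from compound 1 to compound 4 (0.65 log units; beyond the scatter). The change adds a five-membered aromatic ring with a nitrogen and a hydrogen-bond donor and removes the methyl group, all in one step, so this single pair cannot assign the lower number to any one of these features. No measurement here bears on why the number falls.

From the compounds shown here alone, it remains open whether the ring nitrogen hydrogen matters, which 1-methylindol-2-yl or benzofuran-2-yl on the same carbonyl carbon would test. Going by these compounds, it is also open whether 1H-indol-2-yl gives a similar step with the ethylamino or diethylamino group of compound 2 or compound 3 in place of the ethylpiperazine group.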